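This account rests on a few compounds, and the source may have more. Where it says the series, first, only, none or still open, it means among the compounds named here.

Measured compounds and values

Compound 1, `C#CCNCC(O)COc1ccc2c(C)c(Cc3ccccc3)c(=O)oc2c1`: 95500 nM
Compound 2, `Cc1c(Cc2ccccc2)c(=O)oc2cc(OCC(O)CNc3ccc(Br)cc3)ccc12`: > 100000 nM
Compound 3, `Cc1c(Cc2cccc3ccccc23)c(=O)oc2cc(OCC(O)CN3CCC(C(N)=O)CC3)ccc12`: 42400 nM

In an ADME assay on A549 cells (Homo sapiens) for cytotoxicity, read by CellTiter-Glo (on this read-out higher numbers stand for lower toxicity in this test and lower numbers for higher toxicity in this test), compound 1 gives 95500 nM, the highest of the two numbers shown. The nearest number belongs to compound 3, which gives 42400 nM, a gap that lies beyond the scatter. For compound 2 the result is a limit of the assay, > 100000 nM.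

Compound 4, `Cc1c(Cc2ccccc2)c(=O)oc2cc(OCCCNc3nccs3)ccc12`, differs from compound 1 by 2-((1,3-thiazol-2-yl)amino)ethyl in place of 1-hydroxy-2-(propargylamino)ethyl on a saturated chain carbon bound to an oxygen on an aromatic ring. Within the data shown here, only one measured step touches the same part of the molecule: an at least 1.0-fold higher number from compound 1 to compound 2 (0.01 log units; that floor lies within the scatter), a change on the amine nitrogen that left the number essentially where it was, with the one value sitting at the limit of > 100000 nM in this assay, at which 1 of the 3 values shown sits. That step keeps the hydroxyl, whereas the change to compound 4 removes it and brings in an aromatic ring, so the comparison is loose. On this evidence no step beyond the scatter is expected in this assay, and the estimated step is a 1.1-fold lower number from compound 1 to compound 4 (0.03 log units; within the scatter). Compound 4 is therefore expected to give about 90000 nM, within a range of 40000 nM to 200000 nM, with a fair chance that the assay reports only a limit.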

Compound 4, half-maximal cytotoxic concentration: 50100 nM
For compound 4 the middle estimate is 1.8-fold (0.25 log units) above the measured one, within the range that was stated.
By their numbers in this assay, from the lowest: compounds 3, 4 and 1 (each within the scatter of the next, the first and the last beyond it). At a limit, above all of these: compound 2.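

In this assay, putting 3-((1,3-thiazol-2-yl)amino)propyl in place of 2-hydroxy-3-(propargylamino)propyl gives a 1.9-fold lower number from compound 1 to compound 4 (0.28 log units; within the scatter), so a change that removes the hydroxyl and brings in a five-membered aromatic ring still stays inside the scatter at this place. Compound 2 gives only a limit of the assay, > 100000 nM. Compound 4 gives a number, so this is the first change at this place in the chain that can be sized in full rather than only as a floor: the limit of > 100000 nM in this assay, at which 1 of the 4 values shown sits.

Among these compounds, what stays open is how the two parts of this change count on their own, as the single step carries the loss of the hydroxyl and the arrival of the thiazole together, and a 2-hydroxy-3-((1,3-thiazol-2-yl)amino)propyl chain on the same core would separate them. From the compounds shown here alone, it is also open whether the number in this assay would stay within the scatter of compound 1 with a carboxylic acid at the end of the chain, a longer chain, or a pyridine in place of the thiazole.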